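The compounds below may be only part of what the source reports. "The series", "measured", "known", "first", "only" and "open" are said of these compounds alone.

Compound 1 `O=C(Nc1cccc(-n2cc(-c3ccncc3)c(-c3ccc(Cl)c(O)c3)n2)c1)Nc1cccc(C(F)(F)F)c1` gives in a functional assay on RXF 393 cells (Homo sapiens) for inhibition, read by sulforhodamine B assay, with a stated time of 48 h (a lower number here means that less compound is tolerated, a higher number that more compound is tolerated), a value that is only a limit, > 32500 nM.
Compound 2 `COc1cc(-c2nn(-c3cccc(NC(=O)c4cccc(C(F)(F)F)c4)c3)cc2-c2ccncc2)ccc1Cl` gives in this assay likewise only a limit, > 50000 nM.

Within the data shown here, compound 2 therefore stands nowhere as a number: in this assay it is known only as a limit, and the one further value shown, that of compound 1, is a limit as well. Compound 1 sits at the limit of > 32500 nM in this assay, at which 1 of the 2 values shown sits, and compound 2 sits at the limit of > 50000 nM in this assay, at which 1 of the 2 values shown sits. Among the measured compounds shown here, no step between measured compounds is available, so nothing has been measured that links the two.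

Compound 3 `COc1cc(-c2nn(-c3cccc(NC(=O)Nc4ccc(Cl)c(Cl)c4)c3)cc2-c2ccncc2)ccc1Cl` differs from compound 2 by (3,4-dichlorophenyl)amino in place of 3-(trifluoromethyl)phenyl on a carbonyl carbon; cut one bond further out, the change reads (3-(trifluoromethyl)phenyl)carbonyl to (3,4-dichlorophenyl)carbamoyl. Compound 1 already carries a carbamoyl linkage of the same kind and still gives only a limit, so no step beyond the scatter is expected from compound 2 to compound 3, and a limit is the more likely outcome. Compound 3 is estimated at 50000 nM, between 20000 nM and 120000 nM, an expected step of a number no higher from compound 2 to compound 3 (the limit leaves the size open).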

Compound 3, concentration lethal to 50% of the cells: > 50000 nM
Compound 3: no number, only a limit (the forecaster's own chance of this, stated with the estimate: 70%); the middle value sits exactly at the limit.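

In this assay compound 3 gives only a limit, > 50000 nM. Among these compounds, compound 2 also gives only a limit, > 50000 nM, and with two limits no step between these compounds can be read. The compounds shown leave open what number any of them would give, and whether (3,4-dichlorophenyl)amino in place of 3-(trifluoromethyl)phenyl on a carbonyl carbon changes it at all.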